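Trading 3-bromophenyl for 4-methylphenyl on an oxygen

A few compounds are considered here, and "the series" means these few. Any claim that something is new, unique, unknown or untested is made for them only; others in the source may bear on it.

In a functional assay on HT-29 cells (Homo sapiens) for antiproliferative activity, read by sulforhodamine B assay, with a stated time of 48 h (on this read-out higher numbers stand for weaker inhibition and lower numbers for stronger inhibition), compound 1 `Cc1ccccc1OS(=O)(=O)c1ccc(N2CCN(C)C2=O)cc1` gives 4800 nM, compound 2 `CN1CCN(c2ccc(S(=O)(=O)Oc3cccc(Cl)c3)cc2)C1=O` gives 2100 nM and compound 3 `CN1CCN(c2ccc(S(=O)(=O)Oc3cccc(Br)c3)cc2)C1=O` gives 1300 nM. The data show a 1.6-fold lower number from compound 2 to compound 3 (0.21 log units; within the scatter), and also a 3.7-fold lower number from compound 1 to compound 3 (0.57 log units; beyond the scatter), so compound 3 shares the low end of this small range with compound 2. Compound 4 `Cc1ccc(OS(=O)(=O)c2ccc(N3CCN(C)C3=O)cc2)cc1` carries 4-methylphenyl in place of 3-bromophenyl on an oxygen. The closest guide is compound 1, a 2-methylphenyl case, with a 3.7-fold lower number from compound 1 to compound 3 (0.57 log units; beyond the scatter) and a 2.3-fold lower number from compound 1 to compound 2 (0.36 log units; beyond the scatter). For the measured compounds named here, no 4-substituted compound has been measured yet, so only part of that modest gap is expected to return in this assay. The expected move is a 2.3-fold higher number from compound 3 to compound 4 (0.36 log units; beyond the scatter). For compound 4 the estimate is 3000 nM, with an expected range of 1200 nM to 7000 nM.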

Compound 4, half-maximal inhibitory concentration: > 100000 nM
Compound 4 ended at the assay's limit (the forecaster's own chance of this, stated with the estimate: 3%); middle value at least 33-fold (1.52 log units) from the limit.
By their numbers in this assay, from the lowest: compounds 3 and 2 (each within the scatter of the next); then compound 1. At a limit, above all of these: compound 4.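

Compound 4 stands at a limit of the assay, not at a number: the limit of > 100000 nM in this assay, at which 1 of the 4 values shown sits. In this assay, 4-methylphenyl in place of 3-bromophenyl or 3-chlorophenyl gives far larger steps than any seen before, with an at least 76-fold higher number from compound 3 to compound 4 (1.88 log units; beyond the scatter) and an at least 47-fold higher number from compound 2 to compound 4 (1.67 log units; beyond the scatter). Compound 1 and compound 4 differ only in 2-methylphenyl against 4-methylphenyl, yet the data show an at least 20-fold higher number from compound 1 to compound 4 (1.31 log units; beyond the scatter), so where the methyl sits on this ring matters greatly here.

From the compounds shown here alone, whether this loss belongs to the methyl alone or to any group placed as in 4-methylphenyl stays open. 4-Bromophenyl, 4-methoxyphenyl and 3-methylphenyl on this oxygen would separate these readings.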